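From Octyl to Isopropyl: a Weaker Inhibitor Expected

A few compounds are considered here, and "the series" means these few. Any claim that something is new, unique, unknown or untested is made for them only; others in the source may bear on it.

Compound 2 `CCCCCCCCc1cn([C@H]2C[C@@H]3OP(=O)(O)OC[C@H]3O2)c(=O)[nH]c1=O` has the highest number of the three measured compounds in a functional assay on Raji cells (Homo sapiens) (a lower number here means a stronger inhibitor, a higher number a weaker inhibitor), giving 165 ug/mL. Its nearest neighbour is compound 3 `CCCCCCc1cn([C@H]2C[C@H](O)[C@@H](CO)O2)c(=O)[nH]c1=O`, which gives 151 ug/mL in this assay, a gap within the scatter; its furthest is compound 1 `CCCCCCCCc1cn([C@H]2C[C@H](O)[C@@H](CO)O2)c(=O)[nH]c1=O`, which gives 52 ug/mL, a gap beyond the scatter. Compound 4 `CC(C)c1cn([C@H]2C[C@@H]3OP(=O)(O)OC[C@H]3O2)c(=O)[nH]c1=O` differs from compound 2 in one place: isopropyl in place of octyl on an aromatic carbon. Among the compounds with values here, the only measured step bearing on this change is a 2.9-fold higher number from compound 1 to compound 3 (0.46 log units; beyond the scatter), in which removing part of the chain gave a modest rise beyond the scatter. The change to compound 4 removes far more of the chain than that step did, so a step in the same direction, larger than the measured one, is expected, and this assay may then report only a limit. Compound 4 is therefore expected to give 550 ug/mL, within a range from 220 ug/mL to 1500 ug/mL. That estimate means a step of a 3.3-fold higher number from compound 2 to compound 4 (0.52 log units; beyond the scatter).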

Compound 4, concentration for 50% inhibition: > 500 ug/mL
Compound 4: no number, only a limit (the forecaster's own chance of this, stated with the estimate: 35%); the middle value is on the limit's open side.
By their numbers in this assay, from the lowest: compound 1; then compounds 3 and 2 (each within the scatter of the next). At a limit, above all of these: compound 4.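

Compound 4 reaches no number in this assay, only a limit: the limit of > 500 ug/mL in this assay, at which 1 of the 4 values shown sits. From the compounds shown here alone, on this aromatic carbon, isopropyl in place of octyl gives an at least 3.0-fold higher number from compound 2 to compound 4 (0.48 log units; beyond the scatter), so the step is beyond the scatter but its full size stays unknown. The earlier compounds shown here showed a change in the chain only on the core of compound 1, as a 2.9-fold higher number from compound 1 to compound 3 (0.46 log units; beyond the scatter), and this result shows a rise in the same direction on the core of compound 2.

With only a limit for compound 4, the compounds shown cannot tell how steeply the number depends on the chain on this core. They also leave open whether a longer chain than octyl, or an amine at the end of the octyl chain, would move the number on the core of compound 2.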